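The source may hold more compounds than are shown below. What is called first, only, known or untested is meant among the compounds shown, and "the series" means these compounds.

Compound 2 `O=C(NC[C@@H]1C[C@@H]2C=C[C@@H]1C2)NS(=O)(=O)N1CCC(CCNC(=O)c2nc3ccccc3s2)CC1` carries a sulfamoyl urea core shared with compound 1 `COc1ncc(Cl)cc1C(=O)NCCC1CCN(S(=O)(=O)NC(=O)NC[C@@H]2C[C@@H]3C=C[C@@H]2C3)CC1`, and the two differ only at the group on the carbonyl carbon. In a functional assay on the whole organism (blood) with Rattus norvegicus as the target, with stated times of 24 h and 1 h, at a dose of 1 mg/kg by the intraperitoneal route (on this read-out lower numbers stand for a weaker effect and higher numbers for a stronger effect at the one dose given), compound 1 gives 20%, while compound 2 gives 14%; the step of a number 6 percentage points lower from compound 1 to compound 2 (within the scatter) lies within the scatter, so the two stand alongside each other. Compound 3 `O=C(NC[C@@H]1C[C@@H]2C=C[C@@H]1C2)NS(=O)(=O)N1CCC(CCNC(=O)c2cccc3cccnc23)CC1` continues with the same kind of exchange: quinolin-8-yl in place of 1,3-benzothiazol-2-yl on a carbonyl carbon. Within the data shown here, the only step that bears on it, from compound 1 to compound 2, was within the scatter, so no step beyond the scatter is expected in this assay for compound 3, whose value is estimated at 15% (range 5% to 30%), a step of a number 1 percentage points higher from compound 2 to compound 3 (within the scatter).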

Compound 3, a percentage reported as activity, at one dose (the size of the read-out at that dose, not a potency): 32%
Compound 3: the middle estimate sits 17 percentage points below what was measured, and the stated range ends below it.
By their numbers in this assay, from the lowest: compounds 2 and 1 (each within the scatter of the next); then compound 3.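

In this assay the group on the carbonyl carbon now makes a visible difference: quinolin-8-yl in place of 1,3-benzothiazol-2-yl gives a number 18 percentage points higher from compound 2 to compound 3 (beyond the scatter) and in place of 5-chloro-2-methoxypyridin-3-yl gives a number 12 percentage points higher from compound 1 to compound 3 (beyond the scatter) while the earlier exchange between those two groups stayed within the scatter. Both steps are modest, and no available evidence explains them.

The compounds shown leave open whether naphthalen-1-yl on the same carbonyl carbon would match quinolin-8-yl. They also leave open how an amine or a carboxylic acid added to quinolin-8-yl would read.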